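The compounds below may be only part of what the source reports. "The series", "measured", "known", "first", "only" and "open" are said of these compounds alone.

Compound 1 `Cc1c(C(=O)CCc2ccccc2)oc2cc(-c3ccccc3)cc(O)c12` and compound 2 `Cc1c(C(=O)c2ccc(N(C)C)cc2)oc2cc(-c3ccccc3)cc(O)c12` share one core and differ only on the carbonyl carbon. In a functional assay on WI-38 VA13 cells (Homo sapiens) for cytotoxicity (a higher number here means that more compound is needed for the effect, a lower number that less compound is needed), compound 1 gives a limit, > 4 ug/mL, and not a number. In this assay compound 2 likewise gives only a limit, > 4 ug/mL. The step that the two limits leave unreadable from compound 1 to compound 2 is therefore not readable, and compound 2 stands at the limit of > 4 ug/mL in this assay, at which 2 of the 2 values shown sit, with no number of its own.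

Compound 3 `COc1ccccc1C(=O)c1oc2cc(-c3ccccc3)cc(O)c2c1C` differs from compound 2 by 2-methoxyphenyl in place of 4-(dimethylamino)phenyl on a carbonyl carbon. For the measured compounds named here, the only measured step, from compound 1 to compound 2, is the one whose size the two limits hide, so no measured step gives a size for the present change. With both known values at the limit, the expected step that the limit leaves unreadable from compound 2 to compound 3 in this assay is none that can be read beyond the scatter. Compound 3 is therefore estimated at 6 ug/mL, in the range 2 ug/mL to 30 ug/mL, and is expected most likely to be reported again only as a limit.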

Compound 3, half-maximal effective concentration: 0.09 ug/mL
The estimate for compound 3 lay 67-fold (1.82 log units) above the measured number; the measured number lies below the stated range.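

In this assay the group on the carbonyl carbon turns out to be able to move the read-out strongly: 2-methoxyphenyl in place of 4-(dimethylamino)phenyl gives an at least 44-fold lower number from compound 2 to compound 3 (1.64 log units; beyond the scatter) and 2-methoxyphenyl in place of phenethyl gives an at least 44-fold lower number from compound 1 to compound 3 (1.64 log units; beyond the scatter) in the same series. For the compounds shown here, the step between compound 1 and compound 2 cannot be read, so these two are the first sizes available for this place. Both sizes are minimum sizes because compound 1 and compound 2 carry only a limit: the limit of > 4 ug/mL in this assay, at which 2 of the 3 values shown sit.

On these data alone, whether the lower number belongs to the methoxy group or to the phenyl ring that carries it stays open, and a plain phenyl or a hydroxyphenyl group on the carbonyl carbon would separate the two. Going by these compounds alone, with compound 3 the only one holding a number, the full size of both steps also stays open.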